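Cytotoxicity of a Furan-3-yl Analogue in the Same Series

The source may report more compounds than this note shows. Statements on the series, on what has been measured and on what is new or still open speak of the compounds shown alone.

Compound 1 `O=C(c1ccc2c(c1)OCCO2)C1CCN(Cc2coc(-c3ccc(F)c(F)c3)n2)CC1` gives > 150 ug/mL in an ADME assay on HEK293 cells (Homo sapiens) for cytotoxicity, read by MTT assay, with a stated time of 36 h (on this read-out lower numbers stand for stronger inhibition and higher numbers for weaker inhibition), a limit of the assay.
Compound 2 `O=C(c1ccc2c(c1)OCCO2)C1CCN(Cc2coc(-c3ccccc3F)n2)CC1` gives > 150 ug/mL in this assay, also a limit.
Compound 3 `CC(C)(C)c1ccc(-c2nc(CN3CCC(C(=O)c4ccc5c(c4)OCCO5)CC3)co2)cc1` gives > 150 ug/mL in this assay, again a limit.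

Compound 3 therefore stands at the limit of > 150 ug/mL in this assay, at which 3 of the 3 values shown sit, together with the other two measured compounds, and no number separates any of them. The three steps that connect the measured compounds, a step that the two limits leave unreadable from compound 1 to compound 2, a step that the two limits leave unreadable from compound 1 to compound 3 and a step that the two limits leave unreadable from compound 2 to compound 3, are all unreadable, since each joins two limits.

Compound 4 `O=C(c1ccc2c(c1)OCCO2)C1CCN(Cc2coc(-c3ccoc3)n2)CC1` is the next member. It differs from compound 3 by furan-3-yl in place of 4-(tert-butyl)phenyl on an aromatic carbon, the five-membered ring with one hetero atom entering where the six-membered ring of carbon only leaves. Among the measured compounds shown here, none of the measured steps gives a readable size, so they offer no direction for this change; what they show is that three different aryl groups at this position all stayed at the limit. Compound 4 is thus expected to remain at the limit as well, with an estimated 150 ug/mL in this assay, within 90 ug/mL to 250 ug/mL. The step from compound 3 to compound 4 is accordingly estimated at a number no higher from compound 3 to compound 4 (the limit leaves the size open), which is no step beyond the scatter.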

Compound 4, half-maximal inhibitory concentration: > 150 ug/mL
Compound 4: no number, only a limit (the forecaster's own chance of this, stated with the estimate: 85%); the middle value sits exactly at the limit.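

The steps from compound 1, compound 2 and compound 3 to compound 4 cannot be read, since each joins two limits: the limit of > 150 ug/mL in this assay, at which 4 of the 4 values shown sit.

The compounds shown leave open how far apart these four compounds lie in this assay, and whether any other group at this position would give a number rather than a limit.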